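A few compounds are considered here, and "the series" means these few. Any claim that something is new, unique, unknown or untested is made for them only; others in the source may bear on it.

Measured compounds:
compound 1 `C=CCc1c(OC(C)=O)ccc2ccc(=O)oc12` — 0.2 ug/mL
compound 2 `C=CCc1c(OCC(C)=O)ccc2ccc(=O)oc12` — > 20 ug/mL
compound 3 `C=CCc1c(OCCO)ccc2ccc(=O)oc12` — > 20 ug/mL

In an assay on LNCaP cells for inhibition of 3-oxo-5-alpha-steroid 4-dehydrogenase 1 (Homo sapiens) (on this read-out lower numbers stand for stronger inhibition and higher numbers for weaker inhibition), compound 1 gives 0.2 ug/mL. For compound 2 the read-out is a limit of the assay, > 20 ug/mL. For compound 3 the read-out is likewise a limit, > 20 ug/mL. Two of the three values shown thus rest at the limit of > 20 ug/mL in this assay, at which 2 of the 3 values shown sit, and compound 3 stands at that limit rather than at a number. The two measured steps that reach the ethers, an at least 100-fold higher number from compound 1 to compound 2 (2.00 log units; beyond the scatter) and an at least 100-fold higher number from compound 1 to compound 3 (2.00 log units; beyond the scatter), were both large and in the same direction, whereas a step that the two limits leave unreadable from compound 2 to compound 3.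

Compound 4 `C=CCc1c(OCc2ccccc2)ccc2ccc(=O)oc12` differs from compound 3 by phenyl in place of hydroxymethyl on a saturated chain carbon bound to an oxygen on an aromatic ring. Compound 4 keeps an ether on the oxygen on the aromatic ring, as compounds 2 and 3 do, and no measured step reads the change within the ether chain, so nothing shown separates it from the limit. Compound 4 is therefore expected to remain at or near that limit, estimated at 25 ug/mL with a range from 5 ug/mL to 100 ug/mL. This estimate implies a step that the limit leaves unreadable from compound 3 to compound 4, read as an expectation only.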

Compound 4, half-maximal inhibitory concentration: > 4 ug/mL
Compound 4 ended at the assay's limit; the forecaster's own chance of this, stated with the estimate: 70%; the middle value is on the limit's open side.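

Benzyl in place of acetyl on an oxygen on an aromatic ring gives an at least 20-fold higher number from compound 1 to compound 4 (1.30 log units; beyond the scatter) in this assay and extends the loss to a third ether group, now carrying one six-membered aromatic ring of carbon only. Compounds 2, 3 and 4 all stand apart from compound 1, whether the ether chain ends in a ketone, in hydroxymethyl or in phenyl, so none of these ethers matches the acetyl group. Compound 4 rests on a limit of the assay, not on a number: the limit of > 4 ug/mL in this assay, at which 1 of the 4 values shown sits.

The steps among compounds 2, 3 and 4 cannot be read, and no order among these ethers can be given. Going by these compounds, whether a longer ester such as propionyl, a benzoyl ester or a carbamate on that oxygen stays near compound 1 remains open.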